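Phenyl in place of the ester on a coumarin-lipoate hybrid

The source may report more compounds than this note shows. Statements on the series, on what has been measured and on what is new or still open speak of the compounds shown alone.

Of the compounds shown here, two have been measured in a functional assay on PC-12 cells (Rattus norvegicus) for cytotoxicity, read by MTT assay, with stated times of 3 h and 2 h, tested at 50 uM; on this read-out lower numbers stand for a weaker effect and higher numbers for a stronger effect at the one concentration tested. Compound 1 `CC(=O)c1cc2ccc(OCCCCCn3cc(CNC(=O)CCCCC4CCSS4)nn3)cc2oc1=O` gives 18.2%, while compound 2 `CCOC(=O)c1cc2ccc(OCCCCCn3cc(CNC(=O)CCCCC4CCSS4)nn3)cc2oc1=O` gives 40.7%. Within the data shown here, the one recorded step, a number 22.5 percentage points higher from compound 1 to compound 2 (beyond the scatter), is the only comparison available, and on these two numbers compound 2 stands highest, with compound 1 as the sole other point. Compound 3 `O=C(CCCCC1CCSS1)NCc1cn(CCCCCOc2ccc3cc(-c4ccccc4)c(=O)oc3c2)nn1` has not yet been measured in this assay. Its structure differs from that of compound 2 as follows: phenyl in place of ethoxycarbonyl on an aromatic carbon. The measured step from compound 1 to compound 2 concerns a change on a carbonyl carbon, not the replacement of the whole ethoxycarbonyl group by phenyl, so it bears only loosely on the present step. Among the measured compounds shown here, with no closer precedent, the account expects a step of a number 5.7 percentage points lower from compound 2 to compound 3 (within the scatter), which would lie within the scatter. Compound 3 is therefore estimated at 35%, with a range from 12% to 58%.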

Compound 3, a percentage reported as activity, at one concentration (the size of the read-out at that concentration, not a potency): 17.7%
For compound 3 the middle estimate is 17.3 percentage points above the measured one; low and high end bracket the measured number.
By their numbers in this assay, from the lowest: compounds 3 and 1 (each within the scatter of the next); then compound 2.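

In this assay, phenyl in place of ethoxycarbonyl on this aromatic carbon gives a number 23 percentage points lower from compound 2 to compound 3 (beyond the scatter) and so shows that the read-out responds to a change of the whole group at this position. Phenyl in place of acetyl gives a number 0.5 percentage points lower from compound 1 to compound 3 (within the scatter) as its step, which leaves compound 2 alone apart from the other two and shows that a ring of carbon only and a small ketone group cannot be told apart here, while a carbonyl on this carbon does not by itself go with the higher number, as compound 1 carries one. Nothing available explains these numbers.

From the compounds shown here alone, whether the higher number belongs to esters in general stays open, as a methyl ester or a longer ester chain could show. A carboxylic acid or an amide at this position could also fall on either side.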